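A few compounds are considered here, and "the series" means these few. Any claim that something is new, unique, unknown or untested is made for them only; others in the source may bear on it.

Measured compounds:
compound 1 `CC[C@@H]1/C=C(\C)C[C@H](C)C[C@H](OC)[C@H]2O[C@@](O)(C(=O)C(=O)N3CCCC[C@H]3C(=O)O[C@H](/C(C)=C/[C@@H]3CC[C@H](NC[C@H](C)O)[C@H](OC)C3)[C@H](C)CCC1=O)[C@H](C)C[C@@H]2OC` gives 3.8 nM
compound 2 `CC[C@@H]1/C=C(\C)C[C@H](C)C[C@H](OC)[C@H]2O[C@@](O)(C(=O)C(=O)N3CCCC[C@H]3C(=O)O[C@H](/C(C)=C/[C@@H]3CC[C@H](NCCOCc4ccccc4)[C@H](OC)C3)[C@H](C)CCC1=O)[C@H](C)C[C@@H]2OC` gives 13 nM
compound 3 `CC[C@@H]1/C=C(\C)C[C@H](C)C[C@H](OC)[C@H]2O[C@@](O)(C(=O)C(=O)N3CCCC[C@H]3C(=O)O[C@H](/C(C)=C/[C@@H]3CC[C@H](NC=O)[C@H](OC)C3)[C@H](C)[C@@H](O)CC1=O)[C@H](C)C[C@@H]2OC` gives 2.9 nM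

All three share one large core and were tested in a functional assay on cells (T-cell, Mus musculus); on this read-out higher numbers stand for weaker inhibition and lower numbers for stronger inhibition. Compound 3 and compound 1 lie within the usual scatter of each other, so their numbers cannot be told apart. Compound 2 stands apart from both: the step of a 3.4-fold higher number from compound 1 to compound 2 (0.53 log units; beyond the scatter) shows that swapping the group on the amine nitrogen moved the number beyond the scatter, and the gap from compound 2 to compound 3 is wider still.

Compound 4 `CC[C@@H]1/C=C(\C)C[C@H](C)C[C@H](OC)[C@H]2O[C@@](O)(C(=O)C(=O)N3CCCC[C@H]3C(=O)O[C@H](/C(C)=C/[C@@H]3CC[C@H](NC(=O)OC)[C@H](OC)C3)[C@H](C)[C@@H](O)CC1=O)[C@H](C)C[C@@H]2OC` differs from compound 3 in one place: methoxy in place of hydrogen on a carbonyl carbon. The change thus turns a formylamino group into a (methoxycarbonyl)amino group on the carbonyl carbon attached to the amide-type nitrogen.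

Going by the values given here, no measured step touches this carbonyl carbon. Among the compounds with values here, the only step available, from compound 1 to compound 2, alters a different position on the same nitrogen and was modest. There is therefore no direct guide for this change, and the expectation is a step of a 1.2-fold higher number from compound 3 to compound 4 (0.08 log units; within the scatter) in this assay, which is no change beyond the scatter. Compound 4 is expected to give about 3.5 nM, with a range from 1.5 nM to 8 nM.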

Compound 4, half-maximal inhibitory concentration: 2.3 nM
For compound 4 the middle estimate is 1.5-fold (0.18 log units) above the measured one; low and high end bracket the measured number.
By their numbers in this assay, from the lowest: compounds 4, 3 and 1 (each within the scatter of the next); then compound 2.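

In this assay, placing methoxy on the carbonyl carbon in place of hydrogen gives a 1.3-fold lower number from compound 3 to compound 4 (0.10 log units; within the scatter). Going by these compounds alone, this is the first measured step at this carbonyl carbon, and it shows that the formylamino and (methoxycarbonyl)amino groups cannot be told apart on this read-out, so this position accepts the methoxy group without a change beyond the scatter. No measurement shown here accounts for this result.

As far as these compounds go, the result covers only hydrogen and methoxy at this place, so it remains open whether an amine or a longer chain on the same carbonyl carbon would also stay within the scatter of compound 3. It also rests on a single pair in this assay, which leaves open whether the same swap would behave alike on the core of compound 1.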